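This account rests on a few compounds, and the source may have more. Where it says the series, first, only, none or still open, it means among the compounds named here.

Measured compounds:
compound 1, `Cc1c(OCCCCOc2cccc(C(=O)O)c2)ccc(C(=O)CC(C)C)c1O`: 222 nM
compound 2, `Cc1c(OCCCCOc2ccc(C(=O)O)c(Cl)c2)ccc(C(=O)CC(C)C)c1O`: 151 nM
compound 3, `Cc1c(OCCCCOc2cccc(C(=O)O)c2)ccc(C(=O)CC2CCCC2)c1C`: "not active" (no number reported)

In an assay on HEK293 cells for positive allosteric modulation of metabotropic glutamate receptor 2 (Rattus norvegicus), read by thallium flux, with a stated time of 2.5 min (on this read-out lower numbers stand for an effect already at smaller amounts and higher numbers for an effect only at larger amounts of compound), compound 1 gives 222 nM, and compound 2 gives 151 nM. The two differ only by 4-carboxy-3-chlorophenyl in place of 3-carboxyphenyl on an oxygen on a saturated carbon, and this change produced a 1.5-fold lower number from compound 1 to compound 2 (0.17 log units; within the scatter), so the two values cannot be told apart. Compound 3 rests on a different core; the difference between the two cores is not broken down here. In this assay compound 3 was reported as "not active" (no number reported), with no number given.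

Compound 4, `Cc1c(OCCCCOc2ccc(C(=O)O)c(Cl)c2)ccc(C(=O)CC2CCCC2)c1C`, has not yet been measured in this assay. It differs from compound 3 by 4-carboxy-3-chlorophenyl in place of 3-carboxyphenyl on an oxygen on a saturated carbon, the same change, at the same place, as between compound 1 and compound 2. Because that change gave only a 1.5-fold lower number from compound 1 to compound 2 (0.17 log units; within the scatter), it is expected to move compound 4 little from where compound 3 stands, and compound 3 gave no number at all. Compound 4 is therefore expected most likely to be reported again without a number, or at best with a high value; the estimate for compound 4 is 15000 nM, with a range from 3000 nM to 60000 nM.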

Compound 4, half-maximal effective concentration: 2420 nM
Compound 4: the middle estimate sits 6.2-fold (0.79 log units) above what was measured, outside the stated range (below it).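

Within the data shown here, compound 3 was reported without a number, while compound 4 gives 2420 nM and so no step between compound 3 and compound 4 can be read. The compounds shown leave open how large the effect of 4-carboxy-3-chlorophenyl in place of 3-carboxyphenyl is on the core of compound 3. Nothing given here bears on the reason for this result.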